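The source may hold more compounds than are shown below. What is called first, only, known or untested is meant among the compounds shown, and "the series" means these compounds.

Compound 1 `N#CC1(NC(=O)[C@@H]2C[C@@H](S(=O)(=O)c3ccccc3)C[C@H]2C(=O)N2CCOCC2)CC1` carries a morpholin-4-yl group on the carbonyl carbon of its core. Among the measured compounds shown here, in a functional assay on A20 cells (Mus musculus) for inhibition, with stated times of 1 h, 16 h and 24 h (a higher number here means a weaker inhibitor, a lower number a stronger inhibitor), compound 1 gives 12 nM, which is the second highest of the three numbers measured so far. Compound 2 `C[C@@H]1CN(C(=O)[C@@H]2C[C@H](S(=O)(=O)c3ccccc3)C[C@H]2C(=O)NC2(C#N)CC2)C[C@H](C)O1` gives 1 nM, and the step of a 12-fold lower number from compound 1 to compound 2 (1.08 log units; beyond the scatter) shows how much this ring can gain from two added methyl groups. Compound 3 `N#CC1(NC(=O)[C@@H]2C[C@@H](S(=O)(=O)c3ccccc3)C[C@H]2C(=O)N2CC3(COC3)C2)CC1` gives 248 nM, and the step of a 21-fold higher number from compound 1 to compound 3 (1.32 log units; beyond the scatter) shows how much is lost when the six-membered ring is exchanged for two four-membered rings. Compound 4 `N#CC1(NC(=O)[C@@H]2C[C@@H](S(=O)(=O)c3ccccc3)C[C@H]2C(=O)N2CCS(=O)(=O)CC2)CC1` is the next variation at the same place: 1,1-dioxothiomorpholin-4-yl in place of morpholin-4-yl on a carbonyl carbon. Both measured steps bear on it, since each changes the same ring on the same carbonyl carbon, and both were large, one in each direction. Compound 4 keeps a six-membered ring with two hetero atoms, as in compound 1, so a smaller step than either is expected, tending toward a somewhat higher number, a 2.1-fold higher number from compound 1 to compound 4 (0.32 log units; beyond the scatter). Compound 4 is therefore estimated at 25 nM, with a range from 6 nM to 100 nM.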

Compound 4, half-maximal inhibitory concentration: 816 nM
The estimate for compound 4 lay 33-fold (1.51 log units) below the measured number; measured number above the stated range.
By their numbers in this assay, from the lowest: compound 2; then compound 1; then compound 3; then compound 4.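

In this assay, a six-membered ring with two hetero atoms on the carbonyl carbon does not ensure a low number: 1,1-dioxothiomorpholin-4-yl in place of morpholin-4-yl gives a 68-fold higher number from compound 1 to compound 4 (1.83 log units; beyond the scatter) in this series. This exchange costs even more than the two four-membered rings of compound 3, as a 3.3-fold higher number from compound 3 to compound 4 (0.52 log units; beyond the scatter) shows, so ring size alone does not order these compounds. The span at this one place now reaches an 820-fold higher number from compound 2 to compound 4 (2.91 log units; beyond the scatter) across the four compounds, although the rest of the structure stays the same.

Nothing measured here gives a reason for these differences. On these data alone, it remains open how piperidin-1-yl, with a ring carbon in place of the morpholine oxygen, or piperazin-1-yl, with a ring amine there, would compare with compound 1.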